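Selenium in Place of Oxygen on the Carbonyl Carbon

The compounds below may be only part of what the source reports. "The series", "measured", "known", "first", "only" and "open" are said of these compounds alone.

Within the data shown here, compound 2 `CC(=O)Oc1ccccc1C(=O)OCC[Se]C#N` gives 14500 nM in a functional assay on UACC-903 cells (Homo sapiens) for antiproliferative activity, read by MTT assay, with a stated time of 48 h (a lower number here means a stronger inhibitor, a higher number a weaker inhibitor), the highest number among the three compounds measured so far. Compound 1 `CC(=O)Oc1ccccc1C(=O)NCC[Se]C#N` gives 4000 nM in this assay, and compound 3 `CC(=O)Oc1ccccc1C(=O)[Se]CC[Se]C(=O)c1ccccc1OC(C)=O` gives 3600 nM, so compound 2 is the weakest of the set. Compound 4 `CC(=O)Oc1ccccc1C(=O)[Se]CC[Se]C#N` differs from compound 2 in that (a group of 6 heavy atoms (3 carbon, 1 nitrogen, 2 selenium; no ring) in place of a group of 6 heavy atoms (3 carbon, 1 nitrogen, 1 oxygen, 1 selenium; no ring), on a carbonyl carbon). Among the measured compounds shown here, no measured step makes exactly this exchange. For the measured compounds named here, the only single-point step available, a 3.6-fold higher number from compound 1 to compound 2 (0.56 log units; beyond the scatter), shows that changing the group on this carbonyl carbon can move the number well beyond the scatter. Compound 3, which also carries selenium on a carbonyl carbon, gives 3600 nM in this assay, a number close to that of compound 1 and clearly lower than that of compound 2. The writer therefore expects the change into compound 4 to lower the number, by about a 3.6-fold lower number from compound 2 to compound 4 (0.56 log units; beyond the scatter). Compound 4 is estimated at 4000 nM, with a range from 1500 nM to 12000 nM.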

Compound 4, half-maximal inhibitory concentration: 15800 nM
Compound 4: the middle estimate sits 4.0-fold (0.60 log units) below what was measured; measured number outside the range, above it.
By their numbers in this assay, from the lowest: compounds 3 and 1 (each within the scatter of the next); then compounds 2 and 4 (each within the scatter of the next).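

In this assay, putting selenium in place of oxygen on this carbonyl carbon gives no readable difference (a 1.1-fold higher number from compound 2 to compound 4 (0.04 log units; within the scatter)). Against the amide of compound 1, the same selenium-bearing group gives a clear separation (a 4.0-fold higher number from compound 1 to compound 4 (0.60 log units; beyond the scatter)), so among these three compounds, only the nitrogen-bearing compound 1 stands apart. Compound 3 also carries selenium on this carbonyl carbon and gives 3600 nM, while compound 4 gives 15800 nM, so selenium at this place does not by itself set the number.

No available evidence accounts for these results. The compounds shown leave open how a sulfur atom or a methylene group on this carbonyl carbon would read, and whether a longer chain would alter the separation seen with the amide.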